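Cytotoxicity notes on the series, compound 3 to compound 4

The source may hold more compounds than are shown below. What is called first, only, known or untested is meant among the compounds shown, and "the series" means these compounds.

Measured compounds:
compound 1 `COc1ccc([C@H]2CC(=O)N(c3ccccc3N)C2)cc1OC1CCCC1` — in a functional assay on HEK293 cells (Homo sapiens) for cytotoxicity (on this read-out higher numbers stand for lower toxicity in this test and lower numbers for higher toxicity in this test), compound 1 gives > 10000 nM, a limit of the assay.
compound 2 `COc1ccc([C@H]2CC(=O)N(c3ccc(C(F)(F)F)cc3)C2)cc1OC1CCCC1` — in this assay compound 2 gives > 10000 nM, a limit of the assay.
compound 3 `COc1ccc(S(=O)(=O)Nc2cccc(N3C[C@@H](c4ccc(OC)c(OC5CCCC5)c4)CC3=O)c2)cc1` — in this assay compound 3 gives > 10000 nM, a limit of the assay.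

Compound 3 stands at the limit, as do the two others: the limit of > 10000 nM in this assay, at which 3 of the 3 values shown sit. For the measured compounds named here, the only step between measured compounds that differ in one place, a step that the two limits leave unreadable from compound 1 to compound 2, has no readable size, both of its ends being limits. Compound 4 `COc1ccc([C@H]2CC(=O)N(c3cccc(NS(=O)(=O)c4cc(Br)c(Cl)s4)c3)C2)cc1OC1CCCC1` differs from compound 3 in one place: 4-bromo-5-chlorothiophen-2-yl in place of 4-methoxyphenyl on a sulfonyl sulfur. No measured step touches this change, so neither direction nor size can be read from the measured compounds; the three shown all sit at the limit whatever group stands on the nitrogen of the shared core. The expectation for compound 4 is therefore a step of no size beyond the scatter, a step that the limit leaves unreadable from compound 3 to compound 4, and most likely a limit rather than a number once more. Compound 4 is expected at 20000 nM, with a range from 7000 nM to 60000 nM.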

Compound 4, half-maximal cytotoxic concentration: > 10000 nM
Compound 4: only a limit was reported (the forecaster's own chance of this, stated with the estimate: 80%); the middle value lies beyond the limit too.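

In this assay compound 4 gives > 10000 nM, a limit of the assay, so the step from compound 3 to compound 4 cannot be read, and the series stays at one value: the limit of > 10000 nM in this assay, at which 4 of the 4 values shown sit.

The compounds shown leave open whether any change on the shared core shifts the read-out in this assay at all.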